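Cyclohexyl for hexyl on the amide nitrogen

The source may hold more compounds than are shown below. What is called first, only, known or untested is meant among the compounds shown, and "the series" means these compounds.

Compound 1 `CCNC(=O)CC1CCc2cc(OC)c(OC)cc21`: 26%
Compound 2 `CCCCCCNC(=O)CC1CCc2cc(OC)c(OC)cc21`: 41.5%

Among the measured compounds shown here, in a functional assay on the whole organism (strain Wistar) for inhibition, with Rattus norvegicus as the target, read by paw edema, with stated times of 60 min and 2 h, at a dose of 100 mg/kg by the oral route (on this read-out higher numbers stand for more inhibition at the one dose given (going by the name of the read-out) and lower numbers for less inhibition), compound 2 gives 41.5%, the higher of the two numbers; compound 1 gives 26%, and the only measured step, a number 15.5 percentage points higher from compound 1 to compound 2 (beyond the scatter), lengthens the chain on the amide nitrogen. Compound 3 `COc1cc2c(cc1OC)C(CC(=O)NC1CCCCC1)CC2` differs from compound 2 by cyclohexyl in place of hexyl on an amide-type nitrogen. For the measured compounds named here, no measured step swaps a chain for a ring of the same size, so that step gives only indirect guidance. Compound 3 is therefore expected to stay near compound 2, with a step of a number 0.5 percentage points higher from compound 2 to compound 3 (within the scatter) within the scatter. The estimate for compound 3 is 42%, ranging from 26% to 58%.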

Compound 3, a percentage reported as inhibition, in the whole organism at one dose (the size of the read-out at that dose, not a potency): 56%
Estimate against measurement, compound 3: 14 percentage points below; measured number inside the range.
By their numbers in this assay, from the lowest: compound 1; then compound 2; then compound 3.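

With the same six carbons on the amide-type nitrogen, the cyclohexyl ring gave a number 14.5 percentage points higher from compound 2 to compound 3 (beyond the scatter) in this assay and so the arrangement of those carbons matters at this position, not their number alone. Cyclohexyl in place of ethyl gave a number 30 percentage points higher from compound 1 to compound 3 (beyond the scatter) and compound 3 holds the highest of the three numbers. Nothing available explains this gain.

As far as these compounds go, whether a smaller ring such as cyclopentyl, a branched chain such as isopropyl or an aromatic phenyl ring would match cyclohexyl remains open. So does whether the gain would persist at other doses.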